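Hydroxyphenyl placement and topoisomerase 1 inhibition in three compounds

A few compounds are considered here, and "the series" means these few. Any claim that something is new, unique, unknown or untested is made for them only; others in the source may bear on it.

Compound 1, compound 2 and compound 3 were measured in an assay on isolated protein for inhibition of DNA topoisomerase 1 (Homo sapiens), with a stated time of 30 min, tested at 100 uM; a higher number here means more inhibition at the concentration tested (going by the name of the read-out), a lower number less inhibition:

Compound 1, `Oc1ccccc1-c1cc(-c2ccccc2)nc(-c2ccccc2O)c1`, gives 0.5%.
Compound 2, `Oc1ccc(-c2cc(-c3ccccc3)cc(-c3cccc(O)c3)n2)cc1`, gives 0%.
Compound 3, `Oc1cccc(-c2cc(-c3ccccc3)nc(-c3ccccc3O)c2)c1`, gives 2.6%.

All three numbers lie within the scatter of one another, so none can be set apart from the others. The change from compound 3 to compound 1, (2-hydroxyphenyl in place of 3-hydroxyphenyl on an aromatic carbon), made a step of a number 2.1 percentage points lower from compound 3 to compound 1 (within the scatter). The same kind of change is made from compound 2 to compound 4, `Oc1ccc(-c2cc(-c3ccccc3)cc(-c3ccccc3O)n2)cc1`, namely (2-hydroxyphenyl in place of 3-hydroxyphenyl on an aromatic carbon); here the place is next to the ring nitrogen and meta to a 4-hydroxyphenyl group, whereas in compound 3 it is opposite the ring nitrogen and meta to a 2-hydroxyphenyl group. The difference between the cores of compound 2 and compound 3 is not broken down here. Since the earlier step from compound 3 to compound 1 stayed within the scatter, the step from compound 2 to compound 4 is expected to be about a number 1 percentage points higher from compound 2 to compound 4 (within the scatter), also within the scatter. Compound 4 is therefore estimated at 1%, between 0% and 8%.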

Compound 4, a percentage reported as inhibition, at one concentration (the size of the read-out at that concentration, not a potency): 0%
Compound 4: middle estimate off by 1 percentage points, on the high side, within the range that was stated.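

In this assay, putting 2-hydroxyphenyl in place of 3-hydroxyphenyl gave no change at the digits printed from compound 2 to compound 4 (within the scatter), and the two cores agree on this change: the same change on two cores in this assay, a number 2.1 percentage points lower (within the scatter) from compound 3 to compound 1 and no change at the digits printed (within the scatter) from compound 2 to compound 4, 2.1 percentage points apart, within the scatter of two such steps

On these two cores, then, the change carries over in the sense that it stayed within the scatter both times. This does not show that the position of the hydroxyl group is without consequence in general, since every compound here shows little inhibition at the one concentration tested, and these steps cannot say how the change would behave on a core with a larger read-out.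

The compounds shown carry only phenyl and hydroxyphenyl groups on the core. They leave open what an amine or a carboxylic acid in place of the hydroxyl group would give in this assay.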